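This account rests on a few compounds, and the source may have more. Where it says the series, first, only, none or still open, it means among the compounds named here.

Compound 2 `Cc1nccc(N2CCc3nc(C4(C(=O)Nc5ccc(F)cc5)CCC4)ccc32)n1` gives 21 nM in an assay on HeLa cells for inhibition of Indoleamine 2,3-dioxygenase 1 (Homo sapiens) (on this read-out lower numbers stand for stronger inhibition and higher numbers for weaker inhibition), the second highest of the three numbers recorded: compound 1 `Cc1nccc(N2CCc3nc(C4(C(=O)Nc5ccc(Cl)cc5)CCC4)ccc32)n1` gives 12.5 nM and compound 3 `Cc1nccc(N2CCc3nc(C4(NC(=O)c5ccc(Cl)cc5)CCC4)ccc32)n1` gives 46 nM. The step of a 1.7-fold higher number from compound 1 to compound 2 (0.23 log units; within the scatter) lies within the scatter, whereas a 2.2-fold higher number from compound 2 to compound 3 (0.34 log units; beyond the scatter) and a 3.7-fold higher number from compound 1 to compound 3 (0.57 log units; beyond the scatter) are modest. Compound 4 `O=C(C1CC1)N1CCc2nc(C3(C(=O)Nc4ccc(F)cc4)CCC3)ccc21` alters compound 2 in a single place: cyclopropylcarbonyl in place of 2-methylpyrimidin-4-yl on a nitrogen on an aromatic ring in a ring. Going by the values given here, none of the measured steps touches this part of the shared core; they concern the halogen on the aromatic carbon and the amide at the saturated ring carbon, so they give no direct guide in this assay. Among the compounds with values here, with no precedent, compound 4 is estimated at 60 nM, within a range from 15 nM to 300 nM, which means an expected step of a 2.9-fold higher number from compound 2 to compound 4 (0.46 log units; beyond the scatter).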

Compound 4, half-maximal inhibitory concentration: 8 nM
Compound 4: middle estimate off by 7.5-fold (0.88 log units), on the high side; the measured number lies below the stated range.
By their numbers in this assay, from the lowest: compounds 4, 1 and 2 (each within the scatter of the next, the first and the last beyond it); then compound 3.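

The earlier steps shown here left this nitrogen untouched, and in this assay the change here gives a 2.6-fold lower number from compound 2 to compound 4 (0.42 log units; beyond the scatter) and so counts as a modest step. At this position, then, the 2-methylpyrimidin-4-yl group with its six-membered aromatic ring is not needed to keep the number low, since cyclopropylcarbonyl with its three-membered ring of carbon only serves at least as well. No measured evidence explains this step. As far as these compounds go, it remains open whether the same exchange holds on compound 1 or compound 3, and whether an acetyl group, a cyclobutylcarbonyl group or a plain phenyl ring on this nitrogen would read the same.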